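The source may hold more compounds than are shown below. What is called first, only, known or untested is meant among the compounds shown, and "the series" means these compounds.

Compound 1, `Cn1nc2c(=O)n(CC3(O)CCN(Cc4ccc(-c5ccco5)cc4Cl)CC3)cnc2c1-c1ccc(CNS(C)(=O)=O)cc1`, in an assay on isolated protein for inhibition of ubiquitin carboxyl-terminal hydrolase 7 (Homo sapiens), with stated times of 30 min and 2 h (on this read-out lower numbers stand for stronger inhibition and higher numbers for weaker inhibition), gives 65.3 nM.
Compound 2, `Cn1nc2c(=O)n(CC3(O)CCN(Cc4ccc(-c5ccco5)cc4Cl)CC3)cnc2c1-c1ccc(OC(F)F)cc1`, in this assay gives 179 nM.
Compound 3, `Cn1nc2c(=O)n(CC3(O)CCN(Cc4ccc(-c5ccco5)cc4Cl)CC3)cnc2c1-c1ccc(CNC=O)cc1`, in this assay gives 20.9 nM.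

Compound 3 has the lowest number of the three: it sits below compound 1 by a 3.1-fold lower number from compound 1 to compound 3 (0.49 log units; beyond the scatter) and below compound 2 by an 8.6-fold lower number from compound 2 to compound 3 (0.93 log units; beyond the scatter), both beyond the scatter, so on these numbers it is the strongest inhibitor.

Compound 4, `CN(C)Cc1ccc(-c2c3ncn(CC4(O)CCN(Cc5ccc(-c6ccco6)cc5Cl)CC4)c(=O)c3nn2C)cc1`, is not yet measured. It differs from compound 3 in one place: dimethylamino in place of formylamino on a saturated chain carbon bound to an aromatic carbon.

For the measured compounds named here, no measured step swaps a formylamino for a dimethylamino, so the bearing steps are only indirect. The three measured compounds differ from each other in the same outer group, and their spread, from a 2.7-fold higher number from compound 1 to compound 2 (0.44 log units; beyond the scatter) to an 8.6-fold lower number from compound 2 to compound 3 (0.93 log units; beyond the scatter), shows that changes there move the number by a modest amount. A modest rise from compound 3 is therefore expected for compound 4, a 2.4-fold higher number from compound 3 to compound 4 (0.38 log units; beyond the scatter), with the estimate for compound 4 put at 50 nM, in a range from 15 nM to 170 nM.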

Compound 4, half-maximal inhibitory concentration: 131 nM
Beside the measured number, compound 4's estimate is 2.6-fold (0.42 log units) below it, within the range that was stated.
By their numbers in this assay, from the lowest: compound 3; then compounds 1, 4 and 2 (each within the scatter of the next, the first and the last beyond it).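

Swapping formylamino for dimethylamino on a saturated chain carbon bound to an aromatic carbon keeps the heavy-atom count the same, yet in this assay it clearly weakens inhibition (a 6.3-fold higher number from compound 3 to compound 4 (0.80 log units; beyond the scatter)), so this position responds to more than the size of the group. Compound 4 cannot be separated from compound 2 (a 1.4-fold lower number from compound 2 to compound 4 (0.14 log units; within the scatter)) or from compound 1 (a 2.0-fold higher number from compound 1 to compound 4 (0.30 log units; within the scatter)), which leaves compound 3 alone as the strongest of the four. No supporting data accompany these numbers, so the reason for the loss remains unknown.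

As far as these compounds go, it stays open whether the carbonyl, the amide hydrogen or both matter here. An acetylamino group, a methylamino group or a plain primary amine on the same carbon would help tell these apart.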